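Substituent swaps on the benzyl ether ring, antagonist potency

This account rests on a few compounds, and the source may have more. Where it says the series, first, only, none or still open, it means among the compounds named here.

Measured compounds in a functional assay on Vas deferens for antagonist activity at Alpha-1A adrenergic receptor (Rattus norvegicus); on this read-out lower numbers stand for lower potency and higher numbers for higher potency (the scale is a negative logarithm):
compound 1 `COc1cccc(OC)c1OCCNCCOc1ccccc1OCc1cccc(Cl)c1`, 8.12
compound 2 `COc1cccc(OC)c1OCCNCCOc1ccccc1OCc1cccc(C)c1`, 8.3
compound 3 `COc1cccc(COc2ccccc2OCCNCCOc2c(OC)cccc2OC)c1`, 8.3

Compound 3 stands level with compound 2 at the digits given, and its gap to compound 1, a number 0.18 log units higher from compound 1 to compound 3 (within the scatter), is within the scatter. Compound 4 `CCOc1ccc(COc2ccccc2OCCNCCOc2c(OC)cccc2OC)cc1` differs from compound 3 by 4-ethoxyphenyl in place of 3-methoxyphenyl on a saturated chain carbon bound to an oxygen on an aromatic ring. For the measured compounds named here, the steps that bear on this change are the three substituent swaps on the same ring: a number 0.18 log units higher from compound 1 to compound 2 (within the scatter), a number 0.18 log units higher from compound 1 to compound 3 (within the scatter) and no change at the digits printed from compound 2 to compound 3 (within the scatter), each within the scatter. Going by the values given here, no measured step alters where the substituent sits or introduces ethoxy, so the expectation rests on that general insensitivity. Compound 4 is therefore expected to give no step beyond the scatter, a number 0.10 log units lower from compound 3 to compound 4 (within the scatter). The estimate for compound 4 is 8.2, expected between 7.6 and 8.8.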

Compound 4, negative logarithm of the antagonist equilibrium constant: 8.5
Compound 4: the middle estimate sits 0.30 log units below what was measured; low and high end bracket the measured number.
By their numbers in this assay, from the lowest: compounds 1, 2, 3 and 4 (each within the scatter of the next, the first and the last beyond it).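

In this assay, 4-ethoxyphenyl in place of 3-methoxyphenyl on this saturated chain carbon gives a step within the scatter (a number 0.20 log units higher from compound 3 to compound 4 (within the scatter)), and the same holds against 3-methylphenyl (a number 0.20 log units higher from compound 2 to compound 4 (within the scatter)). The set's first step beyond the scatter is modest and appears only against 3-chlorophenyl (a number 0.38 log units higher from compound 1 to compound 4 (beyond the scatter)). The swap alters both the substituent and its ring position, so the compounds shown cannot separate these two changes, and how a carboxylic acid or an amine on this ring would read stays open. No evidence is given that bears on these steps.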